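The source may report more compounds than this note shows. Statements on the series, on what has been measured and on what is new or still open speak of the compounds shown alone.

In a functional assay for inhibition, with Rattus norvegicus as the target (on this read-out lower numbers stand for stronger inhibition and higher numbers for weaker inhibition), compound 1 (`CC(/N=c1\c(O)c(O)\c1=N/c1cccnc1O)C(C)(C)C`) gives > 30000 nM as its read-out, which is a limit of the assay and not a number. Compound 2 (`CCC/N=c1\c(O)c(O)\c1=N/c1cccnc1`) gives > 30000 nM as its read-out, again only a limit. Compound 3 (`Nc1c(Nc2cccnc2)c(=O)c1=O`) gives > 30000 nM as its read-out, also only a limit. Within the data shown here, compound 1 therefore stands with the other two, and the picture so far is the limit of > 30000 nM in this assay, at which 3 of the 3 values shown sit, with no measured step to draw on.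

Compound 4 (`CC(/N=c1\c(O)c(O)\c1=N/c1ccc(Br)cc1)C(C)(C)C`) carries 4-bromophenyl in place of 2-hydroxypyridin-3-yl on a double-bonded nitrogen and otherwise matches compound 1. Among the measured compounds shown here, with no measured step available, the size of the change in this assay can only be judged loosely. A move toward stronger inhibition is expected, though the result may well stay at the limit. The estimated at least 6.0-fold lower number from compound 1 to compound 4 (0.77 log units; beyond the scatter) is accordingly uncertain. For compound 4 the expected value is 5000 nM with an estimated range from 300 nM to 30000 nM in this read-out.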

Compound 4, half-maximal inhibitory concentration: 1260 nM
For compound 4 the middle estimate is 4.0-fold (0.60 log units) above the measured one; the measured number falls inside the stated range.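

In this assay, the position on the double-bonded nitrogen proves able to move the read-out: 4-bromophenyl in place of 2-hydroxypyridin-3-yl gives an at least 23-fold lower number from compound 1 to compound 4 (1.37 log units; beyond the scatter). Compound 4, at 1260 nM, is the only compound shown with a measured number, so the series now has a value from which later changes can be read. Compounds 1, 2 and 3 remain at a limit of the assay, not a number: the limit of > 30000 nM in this assay, at which 3 of the 4 values shown sit.

The single step swaps the ring nitrogen and the hydroxyl for carbon and bromine all at once, so the compounds shown cannot say which of these differences matters. Nor do they show how plain phenyl, 4-chlorophenyl or a phenyl ring carrying a carboxylic acid would read at this place.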